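A few compounds are considered here, and "the series" means these few. Any claim that something is new, unique, unknown or untested is made for them only; others in the source may bear on it.

Compound 1 `CN1CCC(C(=O)N2Cc3c(NC(=O)C4CC4)n[nH]c3C2(C)C)CC1`: > 225000 nM (a limit)
Compound 2 `CN1CCC(C(=O)N2Cc3c(NC(=O)C4CCC4)n[nH]c3C2(C)C)CC1`: > 225000 nM (a limit)

In a physicochemical assay for solubility, at pH 7 (a lower number here means a less soluble compound, a higher number a more soluble compound), compound 2 gives > 225000 nM, which is a limit and not a number. The series offers only (the limit of > 225000 nM in this assay, at which 2 of the 2 values shown sit). Among the compounds with values here, the one measured step is a step that the two limits leave unreadable from compound 1 to compound 2, at the same carbonyl carbon, so it gives no size to carry forward.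

Compound 3 `CN1CCC(C(=O)N2Cc3c(NC(=O)NCc4ccccc4)n[nH]c3C2(C)C)CC1` carries benzylamino in place of cyclobutyl on a carbonyl carbon, with benzylamino in place of cyclobutyl on a carbonyl carbon. Within the data shown here, no measured step covers this change, so the direction is only tentative. A modest fall in this assay is expected, and the estimated step is an at least 1.3-fold lower number from compound 2 to compound 3 (0.12 log units; that floor lies within the scatter). For compound 3 the expected value is 170000 nM, with an estimated range of 50000 nM to 225000 nM.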

Compound 3, solubility: > 225000 nM
Compound 3 gave a limit, no number; the forecaster's own chance of this, stated with the estimate: 50%; middle value at least 1.3-fold (0.12 log units) from the limit.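

No step can be read among compound 1, compound 2 and compound 3, as all three values are limits: the limit of > 225000 nM in this assay, at which 3 of the 3 values shown sit.

The compounds shown leave open whether cyclopropyl, cyclobutyl or benzylamino on the carbonyl carbon changes the read-out in this assay at all.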